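The compounds below may be only part of what the source reports. "The series", "measured", "known", "first", "only" and "open" are said of these compounds alone.

In a functional assay on MCF7 cells (Homo sapiens) for antiproliferative activity, read by MTT assay, with a stated time of 72 h (on this read-out lower numbers stand for stronger inhibition and higher numbers for weaker inhibition), compound 1 `COc1cc(/C=C/c2ccc(C3=C(c4ccc(O)cc4)C4CC(S(=O)(=O)Oc5ccc(Br)cc5)C3O4)cc2)cc(OC)c1` returns > 100000 nM as a limit of the assay and not as a number. Compound 2 `CCc1ccccc1OS(=O)(=O)C1CC2OC1C(c1ccc(/C=C/c3cc(OC)cc(OC)c3)cc1)=C2c1ccc(O)cc1` gives 49800 nM there, and compound 3 `O=S(=O)(Oc1ccccc1Cl)C1CC2OC1C(c1ccc(/C=C/c3cc(O)cc(O)c3)cc1)=C2c1ccc(O)cc1` gives 40400 nM in this assay so that compound 3 stands within the scatter of compound 2, with no order between the two.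

The next step leads to compound 4 `O=S(=O)(Oc1ccc(O)cc1)C1CC2OC1C(c1ccc(/C=C/c3cc(O)cc(O)c3)cc1)=C2c1ccc(O)cc1` and puts 4-hydroxyphenyl in place of 2-chlorophenyl on an oxygen whose other neighbour is the sulfonyl sulfur (4-hydroxyphenyl in place of 2-chlorophenyl on an oxygen).

Among the measured compounds shown here, only one measured step changes the group on such an oxygen: an at least 2.0-fold lower number from compound 1 to compound 2 (0.30 log units; that floor lies within the scatter) with 2-ethylphenyl in place of 4-bromophenyl. Going by these compounds, that step starts from a limit, so its true size stays open. The series holds no measured case of 4-hydroxyphenyl at this place, and the step gives no direction that can be carried over to the new group.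

The starting point for the expectation is therefore compound 3 at 40400 nM in this assay with no shift beyond the scatter anticipated in either direction. The expected step is a 1.2-fold lower number from compound 3 to compound 4 (0.06 log units; within the scatter) on this basis. For compound 4 the estimated value is 35000 nM with an expected range from 12000 nM to 95000 nM as the estimated span.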

Compound 4, half-maximal inhibitory concentration: 14100 nM
The estimate for compound 4 lay 2.5-fold (0.39 log units) above the measured number; measured number inside the range.
By their numbers in this assay, from the lowest: compound 4; then compounds 3 and 2 (each within the scatter of the next). At a limit, above all of these: compound 1.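

In this assay, the group on the oxygen whose other neighbour is the sulfonyl sulfur now has a change of readable size: a 2.9-fold lower number from compound 3 to compound 4 (0.46 log units; beyond the scatter), with 4-hydroxyphenyl in place of 2-chlorophenyl. The entering group has 1 hydrogen-bond donor and 1 hydrogen-bond acceptor where the group it replaces has 0 of each, and this difference in counts goes with the lower number, though one step cannot assign it a cause. Compound 1 stands at a limit, which leaves the only earlier step at this oxygen without a definite size: the limit of > 100000 nM in this assay, at which 1 of the 4 values shown sits.

This single step changes the substituent and its ring position together, so the compounds shown cannot separate the loss of chlorine, the gain of the hydroxyl and the shift from the 2-position to the 4-position. Going by these compounds, it also stays open whether a 4-aminophenyl or 4-carboxyphenyl group on this oxygen would follow compound 4, and whether the same exchange would give a step of similar size with the methoxy groups of compound 2 in place on the shared core.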